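The source may hold more compounds than are shown below. What is called first, only, known or untested is meant among the compounds shown, and "the series" means these compounds.

Series notes. Compound 1 `Cn1nc(-c2nnc(SCCOc3ccccc3F)o2)cc1-c1ccc(C(F)(F)F)cc1` and compound 3 `Cn1nc(-c2ccc(C(F)(F)F)cc2)cc1-c1nnc(SCCOc2ccccc2F)o1` are built from the same atoms joined differently; the difference between the two cores is not broken down here. In a functional assay on MCF7 cells (Homo sapiens) for cytotoxicity, read by MTT assay, with a stated time of 24 h (on this read-out higher numbers stand for weaker inhibition and lower numbers for stronger inhibition), compound 1 gives 23100 nM, and compound 3 gives 33300 nM; these two numbers lie within the scatter of each other. Compound 2 `Cn1nc(-c2nnc(SCc3cccc(Cl)c3Cl)o2)cc1-c1ccc(C(F)(F)F)cc1` carries 2,3-dichlorophenyl in place of (2-fluorophenoxy)methyl on a saturated chain carbon bound to a sulfur on the core of compound 1, and in this assay compound 2 gives 32200 nM; the change itself reads as a 1.4-fold higher number from compound 1 to compound 2 (0.14 log units; within the scatter), so it did not move the read-out beyond the scatter. Compound 4 `Cn1nc(-c2ccc(C(F)(F)F)cc2)cc1-c1nnc(SCc2cccc(Cl)c2Cl)o1` is the unmeasured partner of compound 3 carrying (2,3-dichlorophenyl in place of (2-fluorophenoxy)methyl on a saturated chain carbon bound to a sulfur); the place is worded the same in both pairs, so this is the same change made on the core of compound 3. A step of similar size is expected here, a 1.3-fold higher number from compound 3 to compound 4 (0.10 log units; within the scatter), because the earlier change gave a 1.4-fold higher number from compound 1 to compound 2 (0.14 log units; within the scatter). Compound 4 is accordingly expected to give about 42000 nM in this assay, with the estimate spanning from 20000 nM to 90000 nM.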

Compound 4, half-maximal inhibitory concentration: 60200 nM
For compound 4 the middle estimate is 1.4-fold (0.16 log units) below the measured one; the measured number falls inside the stated range.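

In this assay the change from (2-fluorophenoxy)methyl to 2,3-dichlorophenyl on a saturated chain carbon bound to a sulfur gives a 1.8-fold higher number from compound 3 to compound 4 (0.26 log units; within the scatter) and so stays within the scatter on the core of compound 3. Set beside the same change on the core of compound 1, the two steps do not differ beyond the scatter: the same change on two cores in this assay, a 1.4-fold higher number (0.14 log units; within the scatter) from compound 1 to compound 2 and a 1.8-fold higher number (0.26 log units; within the scatter) from compound 3 to compound 4, 1.3-fold (0.11 log units) apart, within the scatter of two such steps. This shows that the change behaves alike on these two cores, but with neither step beyond the scatter it does not show that the change has a real effect that carries from one core to the other, and two cores cannot speak for the whole series.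

Still open, from the compounds shown here alone, is whether another group on that sulfur-bound chain, such as an amine, a carboxylic acid or a longer chain, would give a step beyond the scatter on either core. Also open, going by these compounds, is whether the two cores would then still respond alike to the same change.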